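Ethylsulfanyl for an ether chain on compound 2

The source may report more compounds than this note shows. Statements on the series, on what has been measured and on what is new or still open speak of the compounds shown alone.

Three close relatives sharing one core have been measured in an assay on isolated protein for inhibition of Polyunsaturated fatty acid 5-lipoxygenase (Rattus norvegicus); a higher number here means a weaker inhibitor, a lower number a stronger inhibitor. Compound 2 `CCOCCC1CN(c2ccccc2)NC1=O` gives 150 nM, the lowest of the three numbers, though only one of its gaps is beyond the scatter. Compound 1 `CCCOCC1CN(c2ccccc2)NC1=O` gives 260 nM. The step of a 1.7-fold lower number from compound 1 to compound 2 (0.24 log units; within the scatter) falls within the usual scatter, so those two cannot be told apart. Compound 3 `CSC1CN(c2ccccc2)NC1=O` gives 320 nM. Here the step of a 2.1-fold higher number from compound 2 to compound 3 (0.33 log units; beyond the scatter) just clears the scatter.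

Compound 4 `CCSC1CN(c2ccccc2)NC1=O` has not yet been measured. Against compound 2 the change is ethylsulfanyl in place of 2-ethoxyethyl on a saturated ring carbon. Within the data shown here, the closest precedent is the step in which methylsulfanyl replaced 2-ethoxyethyl on a saturated ring carbon, which gave a 2.1-fold higher number from compound 2 to compound 3 (0.33 log units; beyond the scatter). Compound 4 carries ethylsulfanyl instead, a longer chain on the sulfur, but the kind of change is the same, so a modest rise in the number is expected rather than no change. Compound 4 is therefore estimated at 270 nM, with a range from 130 nM to 550 nM. That corresponds to an expected step of a 1.8-fold higher number from compound 2 to compound 4 (0.26 log units; within the scatter) in this assay.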

Compound 4, half-maximal inhibitory concentration: 60 nM
Compound 4: middle estimate off by 4.5-fold (0.65 log units), on the high side; the whole stated range lies above it.
By their numbers in this assay, from the lowest: compound 4; then compounds 2, 1 and 3 (each within the scatter of the next, the first and the last beyond it).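

In this assay the swap of 2-ethoxyethyl for ethylsulfanyl on this saturated ring carbon gives a 2.5-fold lower number from compound 2 to compound 4 (0.40 log units; beyond the scatter) and so reverses what methylsulfanyl had suggested: a chain attached through sulfur can do better here than the ether chains, not only worse. The difference that matters is small: adding one methyl to the chain on the sulfur gives a 5.3-fold lower number from compound 3 to compound 4 (0.73 log units; beyond the scatter) and shows that, across these two compounds, this position responds strongly to a minor lengthening of that chain. Replacing propoxymethyl with ethylsulfanyl gives a 4.3-fold lower number from compound 1 to compound 4 (0.64 log units; beyond the scatter) and with all three of these steps beyond the usual scatter, compound 4 is the strongest inhibitor of the four.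

On these data alone, whether a longer chain on the sulfur, such as propylsulfanyl, keeps this gain, and whether an ethoxy group in the same place behaves like ethylsulfanyl, remains open. What lies behind the size of these steps also remains open, with no measurement here that bears on it.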